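The compounds below may be only part of what the source reports. "The series", "measured", "known", "first", "only" and "open" are said of these compounds alone.

In an assay on HEK293 cells for displacement of a labelled ligand from adenosine receptor A2b (Homo sapiens), read by scintillation counting, with a stated time of 30 min, tested at 10 uM (on this read-out lower numbers stand for less inhibition and higher numbers for more inhibition at the one concentration tested (going by the name of the read-out)), compound 1, `COc1cccc2cc(C(=O)Nc3c(C#N)ncn3-c3ccccc3)c(=N)oc12`, gives 9%, a small reading at the single concentration tested. Compound 2, `COc1ccc(-n2cnc(C#N)c2NC(=O)c2cc3cccc(OC)c3oc2=N)cc1`, differs from compound 1 only by a methoxy in place of hydrogen on an aromatic carbon, and in this assay compound 2 gives 5%. The step of a number 4 percentage points lower from compound 1 to compound 2 (within the scatter) lies within the scatter, so compound 2 sits alongside compound 1, the two readings indistinguishable on these numbers.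

Compound 3, `COc1cccc2cc(C(=O)Nc3c(C#N)ncn3-c3ccc(F)cc3)c(=N)oc12`, is derived from compound 2 by the change (fluoro in place of methoxy on an aromatic carbon). Among the measured compounds shown here, the only measured step that bears on this move is a number 4 percentage points lower from compound 1 to compound 2 (within the scatter), which added the same methoxy that compound 3 now loses, and it produced no shift beyond the scatter. Taking the methoxy away again and putting a fluoro in its place is therefore expected to leave the reading essentially where it is, giving an estimated step of a number 2 percentage points higher from compound 2 to compound 3 (within the scatter). Compound 3 is expected to show 7% in this assay, with a likely range from 0% to 20%.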

Compound 3, a percentage reported as inhibition, at one concentration (the size of the read-out at that concentration, not a potency): 30%
For compound 3 the middle estimate is 23 percentage points below the measured one; the whole stated range lies below it.
By their numbers in this assay, from the lowest: compounds 2 and 1 (each within the scatter of the next); then compound 3.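

The position on the six-membered aromatic ring of carbon only, para to a large group, proves able to shift the reading in this assay: going from 4-methoxyphenyl to 4-fluorophenyl gives a number 25 percentage points higher from compound 2 to compound 3 (beyond the scatter) as the step. Fluoro also separates from hydrogen at the same place, with a number 21 percentage points higher from compound 1 to compound 3 (beyond the scatter) as the step, so among the three groups shown, fluoro alone stands apart, while methoxy and hydrogen remain indistinguishable. Nothing available accounts for why fluoro behaves differently from the other two groups.

The compounds shown leave open whether this rise belongs to fluoro in particular or would also appear with chloro, a hydroxyl, an amine or a carboxylic acid at the same place, and whether fluoro would have a similar effect elsewhere on the ring. As far as these compounds go, compound 3 gives 30% at the one concentration tested, a size of effect rather than a potency, so how strongly it acts across a range of concentrations also remains open.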